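The source may hold more compounds than are shown below. What is called first, only, known or untested is meant among the compounds shown, and "the series" means these compounds.

Compound 1 `O=C(C/C=C/c1ccccc1)Nc1nc2ccccc2c(=O)s1` is the reference point of this set. In an in vitro assay on cells for inhibition of Amine oxidase [flavin-containing] B (Homo sapiens), read by fluorescence and Amplex Red, with stated times of 30 min and 45 min (a higher number here means a weaker inhibitor, a lower number a stronger inhibitor), compound 1 gives 39.8 nM, the lowest of the two numbers measured here. Compound 2 `Cc1ccc2nc(NC(=O)CCCc3ccccc3)sc(=O)c2c1` differs from compound 1 in more than one place; in this assay compound 2 gives 94 nM, a higher number whose gap to compound 1 lies beyond the scatter. Compound 3 `O=C(CCc1ccc(Cl)c(Cl)c1)Nc1nc2ccccc2c(=O)s1` gives only a limit of the assay, not a number: in this assay compound 3 reports > 10000 nM, that is the limit of > 10000 nM in this assay, at which 1 of the 3 values shown sits. Compound 4 `COc1cccc(/C=C/CC(=O)Nc2nc3ccccc3c(=O)s2)c1` is compound 1 with a single change, (methoxy in place of hydrogen on an aromatic carbon). Within the data shown here, no measured pair in this set shows such a change, so the expected step is a 1.1-fold higher number from compound 1 to compound 4 (0.05 log units; within the scatter) in this assay, none beyond the usual scatter. Compound 4 is therefore estimated at 45 nM in this assay, with a range from 12 nM to 160 nM.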

Compound 4, half-maximal inhibitory concentration: 238 nM
Estimate against measurement, compound 4: 5.3-fold (0.72 log units) below; the whole stated range lies below it.
By their numbers in this assay, from the lowest: compound 1; then compound 2; then compound 4. At a limit, above all of these: compound 3.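

Replacing phenyl with 3-methoxyphenyl gives a 6.0-fold higher number from compound 1 to compound 4 (0.78 log units; beyond the scatter) in this assay, so inhibition weakens when methoxy is placed on this aromatic carbon, meta to a large group. Among these compounds, the earlier compounds offered no change in a single place, so this is the first direct reading of how this ring responds to substitution. Nothing measured here explains the loss. From the compounds shown here alone, whether a fluorine or a hydroxyl at this position would be tolerated remains open, as does the effect of methoxy on the other ring carbons.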